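The source may report more compounds than this note shows. Statements on the series, on what has been measured and on what is new or still open speak of the compounds shown alone.

Measured so far:
compound 1, `CN1CCN(c2ccc(C3=NN(C(=O)c4ccc(F)cc4)C(c4ccc(N(C)C)cc4)C3)cc2)CC1`: 32.2%
compound 2, `CN1CCN(c2ccc(C3=NN(C(=O)c4ccc(C(F)(F)F)cc4)C(c4ccc(N(C)C)cc4)C3)cc2)CC1`: 93.2%
compound 3, `CN1CCN(c2ccc(C3=NN(S(=O)(=O)c4ccc(F)cc4)C(c4ccc(N(C)C)cc4)C3)cc2)CC1`: 95.7%

In a functional assay on NCI-H1975 cells (Homo sapiens) for inhibition, read by sulforhodamine B assay, tested at 10 uM (a lower number here means less inhibition, a higher number more inhibition at the concentration tested (going by the name of the read-out)), compound 3 gives the highest of the three numbers. Its nearest neighbour is compound 2, and the gap between them, a number 2.5 percentage points higher from compound 2 to compound 3 (within the scatter), lies within the scatter, so the two cannot be ordered; compound 1 sits far lower, as the step of a number 63.5 percentage points higher from compound 1 to compound 3 (beyond the scatter) shows.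

Compound 4, `CN1CCN(c2ccc(C3=NN(S(=O)(=O)c4ccc(Br)cc4)C(c4ccc(N(C)C)cc4)C3)cc2)CC1`, is the next compound in the set. It differs from compound 3 in one place: bromo in place of fluoro on an aromatic carbon.

Within the data shown here, none of the measured steps swaps one halogen for another on the sulfonyl-bearing ring. Among the measured compounds shown here, the closest precedent is a number 61 percentage points higher from compound 1 to compound 2 (beyond the scatter), where a fluoro on the para position of a carbonyl-bearing ring gave way to trifluoromethyl with a large rise; but that rise started from a low number, and on the sulfonyl compound 3 the read-out already stands near the top of the scale. The two large steps from compound 1 say more about the carbonyl-versus-sulfonyl choice than about the halogen. In this assay a change for compound 4 of no more than the scatter is therefore expected, a number 3.7 percentage points lower from compound 3 to compound 4 (within the scatter). Compound 4 is estimated at 92%, within the range 78% to 99%.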

Compound 4, a percentage reported as inhibition, at one concentration (the size of the read-out at that concentration, not a potency): 70.8%
Beside the measured number, compound 4's estimate is 21.2 percentage points above it; the measured number lies below the stated range.
By their numbers in this assay, from the lowest: compound 1; then compound 4; then compounds 2 and 3 (each within the scatter of the next).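

In this assay the sulfonyl series proves sensitive to the halogen at this place on the aromatic ring: bromo in place of fluoro gives a number 24.9 percentage points lower from compound 3 to compound 4 (beyond the scatter) and so the sulfonyl group alone does not keep the read-out near the top. The 4-bromophenyl sulfonyl compound also separates from the 4-(trifluoromethyl)phenyl carbonyl compound, with a number 22.4 percentage points lower from compound 2 to compound 4 (beyond the scatter) on that change, yet it keeps a clear margin over the 4-fluorophenyl carbonyl compound, with a number 38.6 percentage points higher from compound 1 to compound 4 (beyond the scatter) as the step there, so it now occupies a middle place among the four. Nothing available gives a reason for the drop on going from fluoro to bromo.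

The compounds shown leave open how chloro, iodo, methoxy or a nitrile would read at this place on the sulfonyl-bearing ring, and whether trifluoromethyl would hold a high number there as it does on the carbonyl-bearing ring. They also leave open whether bromo on the carbonyl-bearing ring would lower the number in the same way, so the halogen change cannot yet be read apart from the sulfonyl link.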